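Cyclopentyl in place of 4-chloro-2-fluorophenyl

The source may hold more compounds than are shown below. What is called first, only, known or untested is meant among the compounds shown, and "the series" means these compounds.

- compound 1 `CN1C[C@H](C(=O)Nc2ccccc2)[C@@H](c2ccc(/C=C/C(=O)Nc3ccccc3N)cc2)C1` gives 7 mL/min/kg
- compound 2 `CN1C[C@H](C(=O)Nc2ccc(F)c(Br)c2)[C@@H](c2ccc(/C=C/C(=O)Nc3ccccc3N)cc2)C1` gives 15 mL/min/kg
- compound 3 `CN1C[C@H](C(=O)Nc2ccc(Cl)cc2F)[C@@H](c2ccc(/C=C/C(=O)Nc3ccccc3N)cc2)C1` gives 11 mL/min/kg

These numbers come from an in vitro ADME assay on microsomes from liver (Homo sapiens) for pharmacokinetics, read by LC-MS, with a stated time of 10 min, tested at 1 uM (a lower number here means slower removal, a higher number faster removal of the compound), and the three compounds differ only in the group on an amide-type nitrogen. Compound 3 stands in the middle of the three numbers, but it cannot be separated from either neighbour. The steps that reach it are a 1.6-fold higher number from compound 1 to compound 3 (0.20 log units; within the scatter) and a 1.4-fold lower number from compound 2 to compound 3 (0.13 log units; within the scatter) and both are small. Going by the values given here, the only step that clears the scatter is a 2.1-fold higher number from compound 1 to compound 2 (0.33 log units; beyond the scatter) and it is modest.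

Compound 4 `CN1C[C@H](C(=O)NC2CCCC2)[C@@H](c2ccc(/C=C/C(=O)Nc3ccccc3N)cc2)C1` has not yet been measured. Its difference from compound 3 is cyclopentyl in place of 4-chloro-2-fluorophenyl on an amide-type nitrogen and in words this is cyclopentyl in place of 4-chloro-2-fluorophenyl on an amide-type nitrogen. All three measured steps swap one phenyl group for another at this place, so none of them tests a non-aromatic ring there. They offer only a guide to size, and they give no direction. The expected step is a 1.1-fold higher number from compound 3 to compound 4 (0.04 log units; within the scatter) and no move beyond the scatter is expected, although the uncertainty is wide. In this assay compound 4 is expected at 12 mL/min/kg with an estimated range from 6 mL/min/kg to 25 mL/min/kg for the coming measurement.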

Compound 4, clearance: 9 mL/min/kg
Compound 4: the middle estimate sits 1.3-fold (0.12 log units) above what was measured, and the stated range covers the measured number.
By their numbers in this assay, from the lowest: compounds 1, 4, 3 and 2 (each within the scatter of the next, the first and the last beyond it).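

Compound 4 is the only compound shown with a non-aromatic ring on the amide-type nitrogen, and in this assay this change of ring type makes no clear difference: the steps are a 1.2-fold lower number from compound 3 to compound 4 (0.09 log units; within the scatter) and a 1.7-fold lower number from compound 2 to compound 4 (0.22 log units; within the scatter) and a 1.3-fold higher number from compound 1 to compound 4 (0.11 log units; within the scatter) and none of the three clears the scatter. An aromatic ring at this place is therefore not required for a number in the range set by the three phenyl compounds, at least in this series. Going by these compounds alone, compound 4 also falls inside the span from compound 1 to compound 2, the one pair that stands beyond the scatter, so cyclopentyl does not widen that span, and no measurement here offers an explanation for how close these numbers lie.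

The compounds shown carry only rings of carbon at this place, so it remains open how an open chain such as n-butyl, or a group bearing an amine or a carboxylic acid, would read here. One non-aromatic ring size is also a narrow sample, and cyclopropyl or cyclohexyl could still behave differently from cyclopentyl.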